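Removing the Fluorines: Phenyl Analogue of a Thiazole Hydrazone

A few compounds are considered here, and "the series" means these few. Any claim that something is new, unique, unknown or untested is made for them only; others in the source may bear on it.

Compound 1 `COc1cc(/C=N/Nc2nc(-c3ccc(F)c(F)c3)cs2)cc(Br)c1OC` gives 21200 nM in a functional assay on Caco-2 cells (Homo sapiens) for inhibition, read by MTT assay, with a stated time of 48 h (a higher number here means a weaker inhibitor, a lower number a stronger inhibitor), the lowest of the two numbers recorded there; its nearest neighbour is compound 2 `COc1cc(/C=N/Nc2nc(-c3ccc(F)c(F)c3)cs2)c(Br)c(Br)c1OC`, which gives 22800 nM. Within the data shown here, the only measured step, a 1.1-fold higher number from compound 1 to compound 2 (0.03 log units; within the scatter), concerns a different position and falls within the scatter. Compound 3 `COc1cc(/C=N/Nc2nc(-c3ccccc3)cs2)cc(Br)c1OC` differs from compound 1 by phenyl in place of 3,4-difluorophenyl on an aromatic carbon. Among the measured compounds shown here, no measured step bears on this change, so nothing beyond the scatter is expected in this assay, and the step of a 1.2-fold higher number from compound 1 to compound 3 (0.07 log units; within the scatter) is an estimate without support. Compound 3 is therefore estimated at 25000 nM, with a range of 8000 nM to 80000 nM.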

Compound 3, half-maximal inhibitory concentration: 64200 nM
Compound 3: middle estimate off by 2.6-fold (0.41 log units), on the low side; low and high end bracket the measured number.
By their numbers in this assay, from the lowest: compounds 1 and 2 (each within the scatter of the next); then compound 3.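

In this assay the swap of 3,4-difluorophenyl for phenyl gives a 3.0-fold higher number from compound 1 to compound 3 (0.48 log units; beyond the scatter) and so, unlike the bromo change, moves the number beyond the scatter. This position on the thiazole-bearing core therefore responds to the change, although the step is modest and compound 1 remains the stronger inhibitor of this pair. Nothing measured here explains the difference.

As far as these compounds go, whether a single fluorine would keep the number of compound 1 remains open, as does how a chlorine or a methoxy group on the phenyl would read. Also open, from the compounds shown here alone, is whether the same step would appear on the core of compound 2.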